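Replacing the trifluorophenyl group of compound 2

This account rests on a few compounds, and the source may have more. Where it says the series, first, only, none or still open, it means among the compounds named here.

Measured so far in a functional assay on HFF cells (Homo sapiens) for cytotoxicity; a lower number here means a stronger inhibitor, a higher number a weaker inhibitor:
Compound 1 `N#Cc1ccc(/C=C2\SC(=S)N(NS(=O)(=O)c3ccccc3)C2=O)cc1` gives > 100000 nM, which is a limit.
Compound 2 `O=C1/C(=C/c2ccc(F)c(F)c2F)SC(=S)N1NS(=O)(=O)c1ccccc1` gives > 100000 nM, which is a limit.

Compound 2 has no number to start from. In this assay compound 2 reads > 100000 nM, a limit of the assay and not a measured potency. The next compound, compound 3 `Cc1ccc(/C=C2\SC(=S)N(NS(=O)(=O)c3ccccc3)C2=O)cc1C`, differs from it by one group: 3,4-dimethylphenyl in place of 2,3,4-trifluorophenyl on a double-bonded chain carbon bound to a double-bonded ring carbon. This puts 3,4-dimethylphenyl in place of 2,3,4-trifluorophenyl on a double-bonded chain carbon bound to a double-bonded ring carbon.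

Among the compounds with values here, only one measured step touches this place, a step that the two limits leave unreadable from compound 1 to compound 2. Its size cannot be read, so it gives no magnitude to carry over. What remains is the limit of > 100000 nM in this assay, at which 2 of the 2 values shown sit. Because of the limit of > 100000 nM in this assay, at which 2 of the 2 values shown sit, no step beyond the scatter is expected in this assay, and no direction is expected either. Compound 3 is expected to end up as another limit rather than a number. The estimated change is a number no higher from compound 2 to compound 3 (the limit leaves the size open). For compound 3 the expected value is 100000 nM, with an estimated range from 40000 nM to 150000 nM.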

Compound 3, half-maximal inhibitory concentration: > 100000 nM
Compound 3: a limit, no number; the forecaster's own chance of this, stated with the estimate: 75%; the middle value sits exactly at the limit.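

No new step can be read from compound 1 to compound 3 or from compound 2 to compound 3, because all three compounds rest on the same limit: the limit of > 100000 nM in this assay, at which 3 of the 3 values shown sit.

The compounds shown leave open how strong any of them is in this assay, and whether the group on the double-bonded chain carbon makes any difference there.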